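The source may hold more compounds than are shown below. What is called first, only, known or untested is meant among the compounds shown, and "the series" means these compounds.

compound 1 `CCOC(=O)C(=O)Nc1cccc(NC)c1C#N` – 0.1 mg/kg
compound 2 `CCCNc1cccc(NC(=O)C(=O)OCC)c1C#N` – 0.7 mg/kg
compound 3 `CCOC(=O)C(=O)Nc1cccc(N(C)C(C)C)c1C#N` – not yet measured

In a functional assay on the whole organism with Rattus norvegicus as the target (a higher number here means that more compound is needed for the effect, a lower number that less compound is needed), compound 2 at 0.7 mg/kg holds the higher of the two numbers, beyond the scatter from compound 1. The next change is isopropyl(methyl)amino in place of propylamino on an aromatic carbon. Going by the values given here, one measured step bears on it: a 7.0-fold higher number from compound 1 to compound 2 (0.85 log units; beyond the scatter) with ethyl in place of hydrogen on the chain, modest in size. Among the compounds with values here, no measured compound carries isopropyl(methyl)amino, so support is thin. A further modest rise in this assay is expected, estimated as a 2.1-fold higher number from compound 2 to compound 3 (0.33 log units; beyond the scatter) in this direction. Compound 3 is expected at 1.5 mg/kg within 0.3 mg/kg to 7 mg/kg by this estimate.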

Compound 3, dose for half-maximal effect: 1.2 mg/kg
For compound 3 the middle estimate is 1.3-fold (0.10 log units) above the measured one; measured number inside the range.
By their numbers in this assay, from the lowest: compound 1; then compounds 2 and 3 (each within the scatter of the next).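

In this assay, isopropyl(methyl)amino in place of propylamino on the aromatic carbon ortho to a cyano group gives a 1.7-fold higher number from compound 2 to compound 3 (0.23 log units; within the scatter), so this exchange, which takes the count of hydrogen-bond donors in the group from 1 to 0, leaves the number unresolved. The wider gap at this position is a 12-fold higher number from compound 1 to compound 3 (1.08 log units; beyond the scatter), which sets the smallest group shown apart. Nothing available explains either step.

Still open, going by these compounds, is how a free amino group or a longer chain such as butylamino would read at this position. On these data alone, the effect of a carboxylic acid in place of the ethyl ester is also open.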